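Swapping bromo for methyl on the far aryl ring

The source may hold more compounds than are shown below. What is called first, only, known or untested is meant among the compounds shown, and "the series" means these compounds.

Of the compounds shown here, three share one core and have been tested in a functional assay on A549 cells (Homo sapiens) for antiproliferative activity, read by MTT assay, with a stated time of 48 h; a higher number here means a weaker inhibitor, a lower number a stronger inhibitor. Compound 1 `COc1ccc(/C=C/C(=O)Nc2nnc(-c3ccc(Br)cc3)s2)cc1` gives 1.04 ug/mL, the lowest number of the three. Compound 2 `Cc1ccc(/C=C/C(=O)Nc2nnc(-c3ccc(Br)cc3)s2)cc1` gives 1.51 ug/mL, and the step of a 1.5-fold higher number from compound 1 to compound 2 (0.16 log units; within the scatter) lies within the scatter, so these two cannot be ranked. Compound 3 `O=C(/C=C/c1ccc(C(F)(F)F)cc1)Nc1nnc(-c2ccc(Br)cc2)s1` gives 4.68 ug/mL; the step of a 4.5-fold higher number from compound 1 to compound 3 (0.65 log units; beyond the scatter) and the step of a 3.1-fold higher number from compound 2 to compound 3 (0.49 log units; beyond the scatter) are both modest and beyond the scatter.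

Compound 4 `COc1ccc(/C=C/C(=O)Nc2nnc(-c3ccc(C)cc3)s2)cc1` is not yet measured. It differs from compound 1 by methyl in place of bromo on an aromatic carbon. Among the compounds with values here, every measured step changes the group on the aromatic ring attached to the alkene; none touches the ring where this change sits, so no measured step bears directly on it. The three measured values all fall within a modest span, which suggests that a single small exchange on this scaffold moves the number only modestly, and there is nothing here to set a direction.

Compound 4 is therefore expected to give about 1.5 ug/mL in this assay, between 0.6 ug/mL and 4 ug/mL. The expected step is a 1.4-fold higher number from compound 1 to compound 4 (0.16 log units; within the scatter), an estimate that may fall on either side of compound 1.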

Compound 4, half-maximal inhibitory concentration: 0.66 ug/mL
Compound 4: middle estimate off by 2.3-fold (0.36 log units), on the high side, and the stated range covers the measured number.
By their numbers in this assay, from the lowest: compounds 4, 1 and 2 (each within the scatter of the next, the first and the last beyond it); then compound 3.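

With methyl in place of bromo, on an aromatic carbon para to a large group, this assay gives a 1.6-fold lower number from compound 1 to compound 4 (0.20 log units; within the scatter) and this lies within the scatter, so the two compounds cannot be ranked. Within the data shown here, this is the first measured step on the ring that carries the bromo, whereas the earlier steps all changed the group on the ring attached to the alkene. In this one pair, a 4-methylphenyl group stands in for a 4-bromophenyl group with no difference that can be told from the scatter, and nothing available explains this result.

A single pair cannot show whether the same exchange would also make no clear difference with methyl or trifluoromethyl on the ring attached to the alkene, as in compound 2 and compound 3. Going by these compounds, it also remains open how the number would respond at this position to a quite different group, such as an amine, a carboxylic acid or a longer alkyl chain.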